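The source may report more compounds than this note shows. Statements on the series, on what has been measured and on what is new or still open speak of the compounds shown alone.

Values in a functional assay on PC-3 cells (Homo sapiens) for antiproliferative activity, read by MTT assay, with a stated time of 48 h (on this read-out lower numbers stand for stronger inhibition and higher numbers for weaker inhibition), for the compounds measured so far:

- Compound 1 (`COc1ccc(CN(C(=O)CSc2nc3ccccc3s2)c2cc(OC)c(OC)c(OC)c2)cc1C`) gives 34300 nM
- Compound 2 (`COc1ccc(CN(C(=O)CSc2nc3ccccc3s2)c2cc(OC)c(OC)c(OC)c2)cc1`) gives 8460 nM
- Compound 3 (`COc1ccc(CN(C(=O)CSc2nc3cc(Cl)ccc3s2)c2cc(OC)c(OC)c(OC)c2)cc1O`) gives 11200 nM

Compound 2 has a number within the scatter of compound 3 and well under that of compound 1. Compound 4 (`COc1ccc(CN(C(=O)CSc2nc3ccccc3s2)c2cc(OC)c(OC)c(OC)c2)cc1OC`) is compound 2 with one change (methoxy in place of hydrogen on an aromatic carbon): methoxy in place of hydrogen on an aromatic carbon, ortho to a methoxy group. Going by the values given here, compound 1 carries a methyl on that same carbon, and the one measured step here removes it (a 4.1-fold lower number from compound 1 to compound 2 (0.61 log units; beyond the scatter)), a modest step. Compound 3 differs from compound 2 in more than one place, so it offers no clean comparison. A methoxy is not a methyl, so this evidence is thin, yet a higher number in this assay is expected, of about that size or somewhat smaller. The expected change is (a 2.4-fold higher number from compound 2 to compound 4 (0.37 log units; beyond the scatter)). The estimate for compound 4 is 20000 nM (expected range 7000 nM to 50000 nM).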

Compound 4, half-maximal inhibitory concentration: > 80000 nM
Compound 4: only a limit was reported; the forecaster's own chance of this, stated with the estimate: 5%; middle value at least 4.0-fold (0.60 log units) away from the limit.
By their numbers in this assay, from the lowest: compounds 2 and 3 (each within the scatter of the next); then compound 1. At a limit, above all of these: compound 4.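

Compound 4 gives only a limit, not a number: the limit of > 80000 nM in this assay, at which 1 of the 4 values shown sits. Going by these compounds alone, the carbon ortho to a methoxy group tolerates methoxy even less well than the earlier compounds suggested, with an at least 9.4-fold higher number from compound 2 to compound 4 (0.97 log units; beyond the scatter) when methoxy replaces hydrogen and an at least 2.3-fold higher number from compound 1 to compound 4 (0.36 log units; beyond the scatter) when it replaces methyl. So both groups cleanly compared on this carbon, methyl and methoxy, give weaker inhibition than hydrogen. From the compounds shown here alone, how a fluorine, an amine or a longer ether chain would behave on this carbon stays open. Compound 3 cannot settle this, since it differs from compound 2 in more than one place.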